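This account rests on a few compounds, and the source may have more. Where it says the series, first, only, none or still open, it means among the compounds named here.

The measured compounds are compound 1 `COc1ccc(Nc2nc3c(Cl)ncnc3s2)cc1` with 5880 nM, compound 2 `O=[N+]([O-])c1ccc(Nc2nc3c(N4CCCC4)ncnc3s2)cc1` with 3630 nM and compound 3 `Fc1cccc(F)c1Nc1nc2c(Cl)ncnc2s1` with 17200 nM, all in an assay on CHO cells for displacement of a labelled ligand from adenosine receptor A3 (Homo sapiens), read by scintillation counting, with a stated time of 3 h; on this read-out lower numbers stand for stronger inhibition and higher numbers for weaker inhibition.

Compound 2 gives the lowest of the three numbers in this assay. Its gap to compound 1 lies within the scatter, so the two cannot be ranked against each other; its gap to compound 3 lies beyond the scatter, and compound 3 gives the highest number of the three.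

Compound 4 `Cc1ccc(Nc2nc3c(N4CCCC4)ncnc3s2)cc1` differs from compound 2 in one place: methyl in place of nitro on an aromatic carbon. Within the data shown here, no measured pair shows this exchange, so nothing in the data fixes its size or direction. A small step, not beyond the scatter, is expected for a 1.4-fold higher number from compound 2 to compound 4 (0.14 log units; within the scatter). Compound 4 is expected to give about 5000 nM in this assay, in a range from 1500 nM to 16000 nM.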

Compound 4, inhibition constant: 563 nM
The estimate for compound 4 lay 8.9-fold (0.95 log units) above the measured number; the measured number lies below the stated range.
By their numbers in this assay, from the lowest: compound 4; then compounds 2 and 1 (each within the scatter of the next); then compound 3.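

In this assay, the group on this aromatic carbon, para to a large group, proves able to move the number: with methyl in place of nitro there is a 6.4-fold lower number from compound 2 to compound 4 (0.81 log units; beyond the scatter), beyond the scatter. Among these compounds, this is the first single-place change in the set, and the group with no hydrogen-bond acceptors gives the lower number. Nothing available accounts for the size of this step.

Still open, as far as these compounds go, is how an amine, a carboxylic acid or a longer chain would read on this carbon. Also open, from the compounds shown here alone, is whether the same exchange gives a similar step on another core.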